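This account rests on a few compounds, and the source may have more. Where it says the series, first, only, none or still open, it means among the compounds named here.

Working notes on the series.

Compound 1 `CCC(NC(=O)C(CC(C)C)NC(=O)OCc1ccccc1)C(=O)C(=O)NCc1ccccc1` is the reference point. For the measured compounds named here, in an assay on isolated protein for inhibition of Calpain-1 catalytic subunit (Homo sapiens) (on this read-out lower numbers stand for stronger inhibition and higher numbers for weaker inhibition), compound 1 gives 200 nM, the second highest of the three numbers measured so far. Compound 2 `CCC(NC(=O)C(CC(C)C)NC(=O)OCc1ccccc1)C(=O)C(=O)NCc1cc(OC)cc(OC)c1` carries a 3,5-dimethoxyphenyl in place of the phenyl on the saturated chain carbon bound to the amide-type nitrogen and gives 2300 nM in this assay; the change is a 12-fold higher number from compound 1 to compound 2 (1.06 log units; beyond the scatter). Compound 3 `CCC(NC(=O)C(CC(C)C)NC(=O)OCc1ccccc1)C(=O)C(=O)NCc1ccc2ccccc2n1` carries a quinolin-2-yl at the same place and gives 130 nM; the change is a 1.5-fold lower number from compound 1 to compound 3 (0.19 log units; within the scatter). Between the two variants the difference is an 18-fold lower number from compound 2 to compound 3 (1.25 log units; beyond the scatter).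

Compound 4 `CCC(NC(=O)C(CC(C)C)NC(=O)OCc1ccccc1)C(=O)C(=O)NCCCN1CCCc2ccccc21` is not yet measured. Relative to compound 1 the change is 2-(1,2,3,4-tetrahydroquinolin-1-yl)ethyl in place of phenyl on a saturated chain carbon bound to an amide-type nitrogen. The two measured steps at this position show that a larger bicyclic aromatic group is tolerated, compound 3, while the substituted phenyl of compound 2 is not. Neither step covers a flexible two-carbon link to a saturated ring bearing a nitrogen, so the precedent is indirect. A moderate weakening is expected, with wide uncertainty: the step from compound 1 to compound 4 is estimated as a 2.5-fold higher number from compound 1 to compound 4 (0.40 log units; beyond the scatter). For compound 4 the expected value in this assay is 500 nM, within a range from 150 nM to 2000 nM.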

Compound 4, inhibition constant: 370 nM
For compound 4 the middle estimate is 1.4-fold (0.13 log units) above the measured one; measured number inside the range.
By their numbers in this assay, from the lowest: compounds 3, 1 and 4 (each within the scatter of the next, the first and the last beyond it); then compound 2.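

In this assay, the 2-(1,2,3,4-tetrahydroquinolin-1-yl)ethyl group, with 12 heavy atoms and a non-aromatic ring holding a nitrogen, can replace the phenyl of compound 1 on the saturated chain carbon bound to the amide-type nitrogen with a 1.9-fold higher number from compound 1 to compound 4 (0.27 log units; within the scatter) as the result, so this position also accepts a group joined through a flexible ethyl link. The same group gives a 2.8-fold higher number from compound 3 to compound 4 (0.45 log units; beyond the scatter), a modest step that separates it from the quinolin-2-yl group, and a 6.2-fold lower number from compound 2 to compound 4 (0.79 log units; beyond the scatter), which shows that a substituent larger than phenyl does not necessarily carry the penalty seen with 3,5-dimethoxyphenyl. No available measurement explains the differences among these steps.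

The contributions of the ethyl link and the fused ring system remain unseparated, since the ring is shown on only one link length and the link with only one ring. Open questions are how the same 1,2,3,4-tetrahydroquinolin-1-yl group would read on a propyl chain, and how a piperidine ring or a carboxylic acid would read at the end of the ethyl link.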